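The compounds below may be only part of what the source reports. "The series", "measured", "known", "first", "only" and "open" are said of these compounds alone.

Compound 1 `O=c1cc(CNCc2ccccc2Cl)oc2ccc(O)c(O)c12`: in an ADME assay on Huh-7 cells (Homo sapiens) for cytotoxicity (on this read-out higher numbers stand for lower toxicity in this test and lower numbers for higher toxicity in this test), compound 1 gives > 100000 nM, a limit of the assay.
Compound 2 `O=c1cc(CNCc2ccccc2O)oc2ccc(O)c(O)c12`: compound 2 gives > 100000 nM, again a limit.
Compound 3 `O=c1cc(CNCc2cccc(I)c2)oc2ccc(O)c(O)c12`: compound 3 gives > 100000 nM, also a limit.

Compound 3 therefore stands where every measured compound stands: at the limit of > 100000 nM in this assay, at which 3 of the 3 values shown sit, without a number of its own. Compound 4 `O=c1cc(CNCc2cccc(O)c2)oc2ccc(O)c(O)c12` differs from it by hydroxy in place of iodo on an aromatic carbon. The measured steps that touch compound 3, a step that the two limits leave unreadable from compound 1 to compound 3 and a step that the two limits leave unreadable from compound 2 to compound 3, as well as the related exchange a step that the two limits leave unreadable from compound 1 to compound 2, are all unreadable, since both ends sit at the limit, so no size or direction can be taken from them. Compound 4 is accordingly expected to remain at the limit, with a step that the limit leaves unreadable from compound 3 to compound 4 as the estimated step, and the estimate for compound 4 in this assay is 150000 nM, within 100000 nM to 300000 nM.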

Compound 4, half-maximal cytotoxic concentration: > 100000 nM
Compound 4: only a limit was reported; the forecaster's own chance of this, stated with the estimate: 85%; the middle value is on the limit's open side.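

Compound 4 sits at the same limit as compound 1, compound 2 and compound 3, so no step among them can be read: the limit of > 100000 nM in this assay, at which 4 of the 4 values shown sit.

The compounds shown leave open the size and direction of each exchange, and at what concentration any of them becomes cytotoxic.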